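Chain Length on Sulfur in Oxabicyclic Thromboxane Receptor Antagonists

The source may hold more compounds than are shown below. What is called first, only, known or untested is meant among the compounds shown, and "the series" means these compounds.

Measured compounds:
compound 1 `CCCCCCSC[C@H]1C2CCC(O2)[C@H]1C/C=C\CCCC(=O)O` — 3800 nM
compound 2 `CSCSCC1C2CCC(O2)C1C/C=C\CCCC(=O)O` — 700 nM

Of the compounds shown here, two have been tested in a functional assay on a cell-free system (plasma) for inhibition of thromboxane A2 receptor (Homo sapiens); a higher number here means a weaker inhibitor, a lower number a stronger inhibitor. Compound 1 `CCCCCCSC[C@H]1C2CCC(O2)[C@H]1C/C=C\CCCC(=O)O` gives 3800 nM in this assay, while compound 2 `CSCSCC1C2CCC(O2)C1C/C=C\CCCC(=O)O` gives 700 nM. Compound 2 thus stands with the lowest of the two numbers, and its gap to compound 1 lies beyond the usual scatter of such measurements.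

Compound 3 `CCCCCCCCSCC1C2CCC(O2)C1C/C=C\CCCC(=O)O` has not yet been measured. It differs from compound 2 by heptyl in place of methylsulfanyl on a saturated chain carbon bound to a sulfur, so that a single long alkyl chain on the sulfur replaces the short branching seen in compound 2. Compound 1 already carries a long alkyl chain on its sulfur, and its value of 3800 nM lies well above that of compound 2. The account therefore expects compound 3 to lose potency, with the step of a 3.6-fold higher number from compound 2 to compound 3 (0.55 log units; beyond the scatter) reaching beyond the scatter. Compound 3 is estimated at 2500 nM, within a range from 800 nM to 8000 nM.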

Compound 3, half-maximal inhibitory concentration: 547000 nM
For compound 3 the middle estimate is 220-fold (2.34 log units) below the measured one; the measured number lies above the stated range.
By their numbers in this assay, from the lowest: compound 2; then compound 1; then compound 3.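

In this assay, heptyl in place of methylsulfanyl on a saturated chain carbon bound to a sulfur gives a 780-fold higher number from compound 2 to compound 3 (2.89 log units; beyond the scatter), a large step beyond the scatter. Among these compounds, this is the first step at this position that can be read, and it shows that the number responds very strongly to the change from (methylsulfanyl)methyl to octyl. Nothing shown here accounts for the size of this step.

The change removes methylsulfanyl's sulfur and alters the chain length in a single step, so the compounds shown leave open how much of the loss belongs to each. A butyl chain on the sulfur, or a methoxymethyl group in place of (methylsulfanyl)methyl, would be a group to compare at this place.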